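Ring substituent shift on the pyridine of compound 3

The source may report more compounds than this note shows. Statements on the series, on what has been measured and on what is new or still open speak of the compounds shown alone.

Measured so far in an assay on CHO cells for antagonist activity at transient receptor potential cation channel subfamily V member 1 (Homo sapiens), read by FLIPR and calcium flux; on this read-out higher numbers stand for weaker inhibition and lower numbers for stronger inhibition:
compound 1 `CC(C(=O)NCc1ccc(C(F)(F)F)nc1Cl)c1ccc(NS(C)(=O)=O)c(F)c1` gives 0.2 nM
compound 2 `CC(C(=O)NCc1ccc(C(F)(F)F)nc1CCC(C)(C)C)c1ccc(NS(C)(=O)=O)c(F)c1` gives 0.6 nM
compound 3 `CC1C=C(c2nc(C(F)(F)F)ccc2CNC(=O)C(C)c2ccc(NS(C)(=O)=O)c(F)c2)CCC1` gives 0.2 nM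

Compound 3 sits together with compound 1 at the low end of the three numbers; no change at the digits printed from compound 1 to compound 3 (within the scatter), while a 3.0-fold lower number from compound 2 to compound 3 (0.48 log units; beyond the scatter). Compound 4 `CCC1CC=C(c2nc(C(F)(F)F)ccc2CNC(=O)C(C)c2ccc(NS(C)(=O)=O)c(F)c2)CC1` differs from compound 3 in one place: 4-ethylcyclohex-1-en-1-yl in place of 3-methylcyclohex-1-en-1-yl on an aromatic carbon.

Bearing on this step are the two exchanges at the same aromatic carbon already measured: a 3.0-fold higher number from compound 1 to compound 2 (0.48 log units; beyond the scatter) and no change at the digits printed from compound 1 to compound 3 (within the scatter). Both a chloro, a chain and a ring at this position keep the number within a narrow band, so a change of the group on the ring from 3-methylcyclohex-1-en-1-yl to 4-ethylcyclohex-1-en-1-yl is expected to give at most a small step in this assay, in either direction, most likely none beyond the scatter. The estimate for compound 4 is therefore 0.3 nM, with a range from 0.1 nM to 0.9 nM, which means an expected step of a 1.5-fold higher number from compound 3 to compound 4 (0.18 log units; within the scatter).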

Compound 4, inhibition constant: 0.1 nM
Compound 4: middle estimate off by 3.0-fold (0.48 log units), on the high side; the measured number falls inside the stated range.
By their numbers in this assay, from the lowest: compounds 4, 1 and 3 (each within the scatter of the next); then compound 2.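

In this assay, exchanging 3-methylcyclohex-1-en-1-yl for 4-ethylcyclohex-1-en-1-yl gives a 2.0-fold lower number from compound 3 to compound 4 (0.30 log units; within the scatter) and replacing chloro with the same ring gives a 2.0-fold lower number from compound 1 to compound 4 (0.30 log units; within the scatter) so a second substituted cyclohexenyl group also stays level with the chloro compound. Compound 2 stays apart from the rest: the 4-ethylcyclohex-1-en-1-yl group in place of 3,3-dimethylbutyl gives a 6.0-fold lower number from compound 2 to compound 4 (0.78 log units; beyond the scatter) which adds a second ring-bearing compound on the low side of that open chain. No supporting data accompany these numbers to account for them.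

The exchange from compound 3 to compound 4 alters the alkyl group and its place on the ring together, so the two contributions cannot be separated. As far as these compounds go, it remains open whether an unsubstituted cyclohexenyl ring, a phenyl ring or an amine such as morpholine on this aromatic carbon would stay in the same narrow band.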